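The compounds below may be only part of what the source reports. "The series", "measured", "known", "first", "only" and "open" are said of these compounds alone.

Measured so far in an in vivo ADME assay on the whole organism for metabolic stability, with Rattus norvegicus as the target, at a dose of 10 mg/kg by the oral route; on this read-out lower numbers stand for a shorter-lived compound and higher numbers for a longer-lived compound:
compound 1 `CC(C)(CO)Cn1ncn(-c2ccc(N3CCN(c4ccc(OC[C@H]5CO[C@](Cn6cncn6)(c6ccc(F)cc6F)O5)cc4)CC3)cn2)c1=O` gives 3.41 h
compound 2 `CC(C)n1ncn(-c2ccc(N3CCN(c4ccc(OC[C@H]5CO[C@](Cn6cncn6)(c6ccc(F)cc6F)O5)cc4)CC3)nc2)c1=O` gives 1.26 h

Compound 1 stands at the highest of the two numbers in this assay; the nearest is compound 2, whose number is lower by a margin beyond the usual scatter of repeated measurements. Among the measured compounds shown here, no step between two measured compounds differing in one place is available, so the pair is read only by its two values.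

Compound 3 `CC(C)n1ncn(-c2ccc(N3CCN(c4ccc(OC[C@H]5CO[C@](Cn6cncn6)(c6ccc(F)cc6F)O5)cc4)CC3)cn2)c1=O` has not been measured. It differs from compound 1 by isopropyl in place of 2-(hydroxymethyl)-2-methylpropyl on an aromatic nitrogen, in words: isopropyl in place of 2-(hydroxymethyl)-2-methylpropyl on an aromatic nitrogen.

On this change compound 3 is expected to come out lower than compound 1 in this assay, by a step of a 2.0-fold lower number from compound 1 to compound 3 (0.30 log units; within the scatter), which is more than the scatter but short of what separates compound 1 from compound 2. The expectation leans on compound 2, which also carries an isopropyl group and gives 1.26 h in this assay, while its shared core differs from that of compound 3 in one further place, so its value is only a loose guide. Compound 3 is estimated at 1.7 h, within a range from 0.9 h to 3.2 h.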

Compound 3, half-life: 3.45 h
Compound 3: the middle estimate sits 2.0-fold (0.31 log units) below what was measured; measured number above the stated range.
By their numbers in this assay, from the lowest: compound 2; then compounds 1 and 3 (each within the scatter of the next).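

In this assay, isopropyl in place of 2-(hydroxymethyl)-2-methylpropyl on the aromatic nitrogen gives a 1.0-fold higher number from compound 1 to compound 3 (0.01 log units; within the scatter), so this read-out does not separate the two groups at this position, although the leaving group carries a hydrogen-bond donor and a hydrogen-bond acceptor and the entering group carries neither. The isopropyl group therefore does not by itself go with a low number in this assay: compound 2 gives 1.26 h with that group, while compound 3 gives 3.45 h with the same group on a core that differs in one further place. The data offer no measured property that could explain why the two side chains read alike.

On these data alone, it remains open whether this position accepts other groups equally, such as a primary amine, a carboxylic acid or a longer alkyl chain in place of isopropyl on the same nitrogen. As far as these compounds go, it also remains open whether 2-(hydroxymethyl)-2-methylpropyl on the core of compound 2 would give a number like that of its isopropyl partner, or whether the match seen here belongs to the core of compound 1 alone.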